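Inversion of the ring stereocentre: compound 3 to compound 4

The compounds below may be only part of what the source reports. "The series", "measured", "known", "first", "only" and "open" are said of these compounds alone.

Measured so far:
compound 1 `CN1CCN(c2ccc(Nc3ncc4nc(Nc5ccc(F)cc5)n([C@H]5CCNC5)c4n3)cc2)CC1` — "not determined" (no result reported)
compound 2 `CN1CCN(c2ccc(Nc3ncc4nc(Nc5ccc(F)cc5)n([C@@H]5CCNC5)c4n3)cc2)CC1` — "not determined" (no result reported)
compound 3 `CN1CCN(c2ccc(Nc3ncc4nc(Nc5ccc(F)cc5)n([C@@H]5CCN(S(=O)(=O)C6CC6)C5)c4n3)cc2)CC1` — > 10000 nM

Compound 1 and compound 2 are a pair: they are the same molecule apart from the drawn configuration at the saturated ring carbon, which is all that separates them (the fact that compounds 1 and 2 differ only in the configuration as drawn). In a functional assay on A-431 cells (Homo sapiens) for antiproliferative activity, read by MTT assay, with a stated time of 72 h (on this read-out higher numbers stand for weaker inhibition and lower numbers for stronger inhibition), compound 1 gives "not determined" (no result reported), and compound 2 likewise gives "not determined" (no result reported), so neither carries a number. Compound 3 in this assay gives > 10000 nM; this is a limit of the assay, not a measured number (the limit of > 10000 nM in this assay, at which 1 of the 3 values shown sits). Within the data shown here, compound 3 therefore stands at the limit, with the other two entries holding no number at all, and no step between measured compounds can be read from these three.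

Compound 4 `CN1CCN(c2ccc(Nc3ncc4nc(Nc5ccc(F)cc5)n([C@H]5CCN(S(=O)(=O)C6CC6)C5)c4n3)cc2)CC1` is the next entry. Its relation to compound 3 is as follows: the two compounds have the same atoms and bonds and differ only in configuration as drawn: 1 of 1 stereo elements differ; a stereocentre at a saturated ring carbon is drawn R in compound 3 and S in compound 4. The pair compound 1 and compound 2 offers no numbers to judge what such an inversion does here. With compound 3 at the limit, the step of an at least 1.2-fold lower number from compound 3 to compound 4 (0.09 log units; that floor lies within the scatter) is expected to be small, with a sizeable chance that compound 4 also stops at the limit. Compound 4 is estimated in this assay at 8000 nM, within 1000 nM to 30000 nM.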

Compound 4, half-maximal inhibitory concentration: 1670 nM
Compound 4: middle estimate off by 4.8-fold (0.68 log units), on the high side, within the range that was stated.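

Unlike the pair compound 1 and compound 2, which holds no numbers, this pair gives a readable result in this assay: inverting the saturated ring carbon from R to S gives an at least 5.9-fold lower number from compound 3 to compound 4 (0.77 log units; beyond the scatter). With atoms and bonds unchanged, this step can be traced to the drawn configuration at that single stereocentre alone: the fact that compounds 3 and 4 differ only in the configuration as drawn

For compound 3, > 10000 nM is a limit of the assay and not a number, so the size of the step stands only as a floor.

Steps involving compound 1 or compound 2 cannot be read, so the compounds shown leave open what the inversion does when the cyclopropylsulfonyl group is absent. As far as these compounds go, it also remains open whether the same configuration gives a step of similar size with an acetyl group or a plain methyl group in place of the cyclopropylsulfonyl group.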